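The source may report more compounds than this note shows. Statements on the series, on what has been measured and on what is new or still open speak of the compounds shown alone.

In a functional assay on the whole organism (strain albino) for inhibition, with Rattus norvegicus as the target, read by paw edema, with a stated time of 1 h, at a dose of 20 mmol/kg by the intraperitoneal route (a higher number here means more inhibition at the dose given (going by the name of the read-out), a lower number less inhibition), the measured compounds are:
compound 1 `N#CC1=C(NCC(=O)N2CCOCC2)N(c2ccccc2)C(=O)N2CCCCC(N3CCCC3)C12`, giving 43.9%;
compound 2 `N#CC1=C(NCN2CCCC2)N(c2ccccc2)C(=O)N2CCCCC(N3CCCC3)C12`, giving 22.9%.

Among the measured compounds shown here, compound 2 stands lowest of the two numbers, with compound 1 as its only neighbour. Compound 3 `N#CC1=C(NCC(=O)O)N(c2ccccc2)C(=O)N2CCCCC(N3CCCC3)C12` differs from compound 2 by carboxy in place of pyrrolidin-1-yl on a saturated chain carbon bound to an amine nitrogen. Because a number 21 percentage points lower from compound 1 to compound 2 (beyond the scatter) accompanied pyrrolidin-1-yl entering for a group built around a carbonyl, the reverse move, pyrrolidin-1-yl leaving for carboxy, which also carries a carbonyl, is expected to raise the number, with wide uncertainty since carboxy is not (morpholin-4-yl)carbonyl. For compound 3 the expected step is a number 12.1 percentage points higher from compound 2 to compound 3 (beyond the scatter). Compound 3 is estimated at 35%, ranging from 15% to 55%.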

Compound 3, a percentage reported as inhibition, in the whole organism at one dose (the size of the read-out at that dose, not a potency): 67.2%
For compound 3 the middle estimate is 32.2 percentage points below the measured one, and the stated range ends below it.
By their numbers in this assay, from the lowest: compound 2; then compound 1; then compound 3.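

At this saturated chain carbon bound to an amine nitrogen, carboxy gives the highest number of the three in this assay: replacing pyrrolidin-1-yl gives a number 44.3 percentage points higher from compound 2 to compound 3 (beyond the scatter), and hydroxy in place of morpholin-4-yl on a carbonyl carbon gives a number 23.3 percentage points higher from compound 1 to compound 3 (beyond the scatter). A carbonyl at this place is therefore not enough to set the number, as compound 1 and compound 3 both carry one yet stand apart. Nothing measured here accounts for the rise.

Going by these compounds, what an ester or a primary amide would give on this carbonyl carbon remains open. So does the effect of a longer chain carrying the carboxylic acid.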